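Positional methyl swap on the triazole-linked aryl, compound 4

The source may hold more compounds than are shown below. What is called first, only, known or untested is meant among the compounds shown, and "the series" means these compounds.

Measured compounds:
compound 1 `O=c1[nH]cc(S(=O)(=O)Nc2ccccc2-c2cn(-c3ccccc3)nn2)c(=O)[nH]1` — 11800 nM
compound 2 `Cc1ccc(-n2cc(-c3ccccc3NS(=O)(=O)c3c[nH]c(=O)[nH]c3=O)nn2)cc1` — 6390 nM
compound 3 `Cc1ccccc1-n1cc(-c2cccc(NS(=O)(=O)c3c[nH]c(=O)[nH]c3=O)c2)nn1` — 9230 nM

All three values come from a functional assay on SGC-7901 cells (Homo sapiens) for antiproliferative activity, read by MTT assay, with a stated time of 24 h; on this read-out higher numbers stand for weaker inhibition and lower numbers for stronger inhibition. Compound 3 stands second highest of the three, and its gaps to compound 1 and compound 2 both fall within the scatter, so no order among them is claimed.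

Compound 4 `Cc1ccc(-n2cc(-c3cccc(NS(=O)(=O)c4c[nH]c(=O)[nH]c4=O)c3)nn2)cc1` differs from compound 3 by 4-methylphenyl in place of 2-methylphenyl on an aromatic nitrogen. Among the measured compounds shown here, the only measured step that bears on a methyl change, a 1.8-fold lower number from compound 1 to compound 2 (0.27 log units; within the scatter), was itself within the scatter; no measured pair isolates a move of the methyl around the ring. Compound 2, which also carries a 4-methylphenyl, gives 6390 nM in this assay. The expected step of a 1.2-fold lower number from compound 3 to compound 4 (0.06 log units; within the scatter) is therefore none beyond the scatter, and compound 4 is estimated at 8000 nM, with a range from 4000 nM to 16000 nM.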

Compound 4, half-maximal inhibitory concentration: 9430 nM
For compound 4 the middle estimate is 1.2-fold (0.07 log units) below the measured one; the measured number falls inside the stated range.
By their numbers in this assay, from the lowest: compounds 2, 3, 4 and 1 (each within the scatter of the next).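

In this assay, among the compounds shown here, the swap of 2-methylphenyl for 4-methylphenyl on the aromatic nitrogen gives a 1.0-fold higher number from compound 3 to compound 4 (0.01 log units; within the scatter) and is the first measured pair to isolate a move of the methyl around this ring. On the core of compound 3, the two methyl placements therefore cannot be told apart at this position. No measurement shown offers an explanation for this result.

As far as these compounds go, whether a carboxylic acid or an amine on this phenyl ring would give a step beyond the scatter remains open. So does whether the same methyl move would read alike on the core of compound 2.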